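Swapping nitro for chloro on the aryl sulfonamide of compound 1

The source may report more compounds than this note shows. Statements on the series, on what has been measured and on what is new or still open speak of the compounds shown alone.

Measured compounds:
compound 1 `O=[N+]([O-])c1ccc(S(=O)(=O)NCCCCCCNCc2ccc(Br)cc2)cc1`: 9800 nM
compound 2 `O=S(=O)(NCCCNCC1COc2ccccc2O1)c1cc(C(F)(F)F)cc(C(F)(F)F)c1`: 2600 nM
compound 3 `O=S(=O)(NCCCCCCNCc1ccc(Br)cc1)c1cc(C(F)(F)F)cc(C(F)(F)F)c1`: 2970 nM

In a functional assay on MIA PaCa-2 cells (Homo sapiens) for inhibition, read by MTT assay, with a stated time of 72 h (a lower number here means a stronger inhibitor of growth, a higher number a weaker inhibitor of growth), compound 1 stands highest of the three numbers. Its nearest neighbour is compound 3, whose value of 2970 nM lies beyond the scatter below it, and compound 2 sits further away still with 2600 nM. Compound 4 `O=S(=O)(NCCCCCCNCc1ccc(Br)cc1)c1ccc(Cl)cc1` has not yet been measured. It differs from compound 1 in one place: chloro in place of nitro on an aromatic carbon. For the measured compounds named here, no measured pair shows this exact change, so any expectation rests on the three numbers alone. Compound 4 is expected to give a modest lowering from compound 1, a 1.6-fold lower number from compound 1 to compound 4 (0.21 log units; within the scatter), a step that may well stay within the scatter. Compound 4 is therefore estimated at 6000 nM, with a range from 2000 nM to 18000 nM.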

Compound 4, concentration for 50% growth inhibition: 5900 nM
Compound 4: middle estimate off by 1.0-fold (0.01 log units), on the high side, within the range that was stated.
By their numbers in this assay, from the lowest: compounds 2, 3, 4 and 1 (each within the scatter of the next, the first and the last beyond it).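

Chloro in place of nitro on this aromatic carbon gives a 1.7-fold lower number from compound 1 to compound 4 (0.22 log units; within the scatter) in this assay, the first direct reading of any change at this position. On this core, then, the 4-nitrophenyl can give way to the 4-chlorophenyl, with three heavy atoms replaced by one and both hydrogen-bond acceptors lost, without a change that stands clear of the scatter. Nothing available bears on why the step is this size.

As far as these compounds go, whether an amine, a carboxylic acid or a methoxy group at this position would move the number further remains open. So does whether the same swap would read alike with a shorter chain.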